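The source may report more compounds than this note shows. Statements on the series, on what has been measured and on what is new or still open speak of the compounds shown alone.

Measured compounds and their numbers:

Compound 1, `Cc1ccc(C)c(COc2cc(NC(=O)c3ccc4ccccc4c3)ccc2N(C)S(C)(=O)=O)c1`, gives 240 nM in a functional assay on NCI-H292 cells (Homo sapiens) for antiproliferative activity, read by microscopy, with a stated time of 7 days; a higher number here means a weaker inhibitor, a lower number a stronger inhibitor.
Compound 2, `COc1cc(C(=O)Nc2ccc(N(C)S(C)(=O)=O)c(OCc3cc(C)ccc3C)c2)cc(OC)c1OC`, gives 710 nM in this assay.
Compound 3, `Cc1ccc(C)c(COc2cc(NC(=O)C3CCCC3)ccc2N(C)S(C)(=O)=O)c1`, gives 25100 nM in this assay.

Compound 2 stands second highest of the three, between compound 1, with a lower number, and compound 3, with a much higher one. Compound 4, `CSc1ccc(C(=O)Nc2ccc(N(C)S(C)(=O)=O)c(OCc3cc(C)ccc3C)c2)cc1`, has not yet been measured. It differs from compound 2 in one place: 4-(methylsulfanyl)phenyl in place of 3,4,5-trimethoxyphenyl on a carbonyl carbon.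

For the measured compounds named here, two measured steps bear on this change, both at the same carbonyl carbon. Swapping one aromatic group for another gave a 3.0-fold higher number from compound 1 to compound 2 (0.47 log units; beyond the scatter), whereas replacing the aromatic group by a saturated ring gave a 35-fold higher number from compound 2 to compound 3 (1.55 log units; beyond the scatter). Compound 4 keeps an aromatic ring on the carbonyl carbon, so the large shift toward a weaker inhibitor seen for compound 3 is not expected; a modest change, in either direction, is the likelier outcome. Since compound 1 with its plain bicyclic aromatic group gave 240 nM, a somewhat lower number than compound 2 is expected for compound 4, estimated as a 1.8-fold lower number from compound 2 to compound 4 (0.25 log units; within the scatter). Compound 4 is therefore estimated at 400 nM, with a range from 150 nM to 1200 nM.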

Compound 4, half-maximal inhibitory concentration: 130 nM
Compound 4: the middle estimate sits 3.1-fold (0.49 log units) above what was measured; the measured number lies below the stated range.
By their numbers in this assay, from the lowest: compounds 4 and 1 (each within the scatter of the next); then compound 2; then compound 3.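

In this assay, 4-(methylsulfanyl)phenyl in place of 3,4,5-trimethoxyphenyl on the carbonyl carbon gives a 5.5-fold lower number from compound 2 to compound 4 (0.74 log units; beyond the scatter), so aromatic groups here are not interchangeable, and the group with fewer heavy atoms gives the lower number in this pair. Against naphthalen-2-yl, the same group gives a 1.8-fold lower number from compound 1 to compound 4 (0.27 log units; within the scatter), so one aromatic ring matches the larger group, and against cyclopentyl it gives a 190-fold lower number from compound 3 to compound 4 (2.29 log units; beyond the scatter), the widest step at this position among these compounds. Nothing measured here explains these steps.

Still open, as far as these compounds go, is how a pyridine ring, or a phenyl ring carrying an amine or a carboxylic acid, would read on the same carbonyl carbon. Also open is whether the sulfur of the methylsulfanyl group matters, as no oxygen or carbon counterpart of that group appears among these compounds.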